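Adding a methyl group to compound 1

This account rests on a few compounds, and the source may have more. Where it says the series, first, only, none or still open, it means among the compounds named here.

In a functional assay on the whole organism with Canis familiaris (Canis lupus familiaris) as the target (a higher number here means that more compound is needed for the effect, a lower number that less compound is needed), compound 1 `c1ccc(-c2nc3cc[nH]cc-3n2)cc1` gives 2.5 mg/kg. That lies within the scatter of compound 3 `Cc1ccccc1-c1nc2cc[nH]cc-2n1` at 2.2 mg/kg, while compound 2 `CS(=O)(=O)c1ccc(-c2nc3cc[nH]cc-3n2)cc1` needs more, at 7.5 mg/kg. Compound 4 `Cc1cccc(-c2nc3cc[nH]cc-3n2)c1` carries methyl in place of hydrogen on an aromatic carbon. The same kind of swap elsewhere on the ring gave a 1.1-fold lower number from compound 1 to compound 3 (0.06 log units; within the scatter), a step within the scatter. Methylsulfonyl in place of hydrogen gave a 3.0-fold higher number from compound 1 to compound 2 (0.48 log units; beyond the scatter), beyond the scatter, but that group is not methyl and so bears less directly. The expected step is therefore small, in neither clear direction: a 1.0-fold lower number from compound 1 to compound 4 (0.02 log units; within the scatter). For compound 4 the estimated value is 2.4 mg/kg, with an expected range of 1.2 mg/kg to 4.8 mg/kg.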

Compound 4, dose for half-maximal effect: 1 mg/kg
Compound 4: the middle estimate sits 2.4-fold (0.38 log units) above what was measured; the measured number lies below the stated range.
By their numbers in this assay, from the lowest: compound 4; then compounds 3 and 1 (each within the scatter of the next); then compound 2.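

Methyl in place of hydrogen, meta to a group of 9 heavy atoms, is the first small change here to lower the number beyond the scatter in this assay, with a 2.5-fold lower number from compound 1 to compound 4 (0.40 log units; beyond the scatter). The same group elsewhere on the ring gave only a 1.1-fold lower number from compound 1 to compound 3 (0.06 log units; within the scatter), so on these compounds the place of the methyl makes a difference. Nothing available explains this result.

As far as these compounds go, it remains open whether a longer chain such as ethyl, or an amine or a carboxylic acid, in that same place would lower the number further or raise it.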